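A few compounds are considered here, and "the series" means these few. Any claim that something is new, unique, unknown or untested is made for them only; others in the source may bear on it.

Working notes, benzylamine series. Three analogues share one core and differ only in the aryl group on the saturated chain carbon bound to the amine nitrogen. In a functional assay on MIA PaCa-2 cells (Homo sapiens) for inhibition, read by MTT assay, with a stated time of 72 h (on this read-out higher numbers stand for weaker inhibition of growth and lower numbers for stronger inhibition of growth), compound 1 `COc1ccc(CNCCCNS(=O)(=O)c2cc(C(F)(F)F)cc(C(F)(F)F)c2)cc1OC` gives 2800 nM; compound 2 `O=S(=O)(NCCCNCc1ccc(C(F)(F)F)cc1)c1cc(C(F)(F)F)cc(C(F)(F)F)c1` gives 2500 nM; compound 3 `O=S(=O)(NCCCNCc1ccc(Br)cc1)c1cc(C(F)(F)F)cc(C(F)(F)F)c1` gives 2300 nM. Compound 3 sits at one end of these three numbers, but none of the three is separated from it by more than the scatter: a 1.2-fold lower number from compound 1 to compound 3 (0.09 log units; within the scatter), a 1.1-fold lower number from compound 2 to compound 3 (0.04 log units; within the scatter), and between the other two a 1.1-fold lower number from compound 1 to compound 2 (0.05 log units; within the scatter).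

Compound 4 `O=S(=O)(NCCCNCc1cccc(Cl)c1)c1cc(C(F)(F)F)cc(C(F)(F)F)c1` carries the change (3-chlorophenyl in place of 4-bromophenyl on a saturated chain carbon bound to an amine nitrogen). The steps bearing on it are the aryl swaps already seen, 3,4-dimethoxyphenyl to 4-(trifluoromethyl)phenyl to 4-bromophenyl, all within the scatter, so no step beyond the scatter is expected in this assay in either direction. For compound 4 the estimate is therefore 2400 nM, range 1200 nM to 4800 nM. The expected step is a 1.0-fold higher number from compound 3 to compound 4 (0.02 log units; within the scatter).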

Compound 4, concentration for 50% growth inhibition: 4400 nM
For compound 4 the middle estimate is 1.8-fold (0.26 log units) below the measured one, and the stated range covers the measured number.
By their numbers in this assay, from the lowest: compounds 3, 2, 1 and 4 (each within the scatter of the next).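

In this assay, 3-chlorophenyl on a saturated chain carbon bound to an amine nitrogen stays within the scatter against 4-bromophenyl (a 1.9-fold higher number from compound 3 to compound 4 (0.28 log units; within the scatter)), against 4-(trifluoromethyl)phenyl (a 1.8-fold higher number from compound 2 to compound 4 (0.25 log units; within the scatter)) and against 3,4-dimethoxyphenyl (a 1.6-fold higher number from compound 1 to compound 4 (0.20 log units; within the scatter)). The flat picture at this place therefore extends to a fourth aryl group, one carrying chlorine as its only substituent, and no aryl group among the four separates from the others. No measurement at hand bears on why these numbers stay so close.

The swap from compound 3 to compound 4 changes both the halogen and its place on the ring, and 4-chlorophenyl would separate the two. Going by these compounds, whether a pyridine ring, a cyclohexyl group or a longer chain on the amine nitrogen would move the number beyond the scatter remains open.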